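The source may report more compounds than this note shows. Statements on the series, on what has been measured and on what is new or still open speak of the compounds shown alone.

In a functional assay on HeLa cells (Homo sapiens) for antiproliferative activity, read by MTT assay, with a stated time of 72 h (on this read-out lower numbers stand for stronger inhibition and higher numbers for weaker inhibition), compound 1 `O=C1COc2ccc(-c3cccc(NS(=O)(=O)c4ccc(F)cc4)c3)cc2N1c1ccccc1` gives 17700 nM. Compound 3 `O=C1COc2ccc(-c3cnc(Cl)c(NS(=O)(=O)c4ccc(F)cc4)c3)cc2N1C1CC1`, which differs from it in several places, gives 7180 nM. That is a lower number, beyond the scatter, which leaves compound 1 with the higher of the two exact values. Compound 2 `O=C1COc2ccc(-c3cnc(Cl)c(NS(=O)(=O)c4ccc(F)cc4)c3)cc2N1c1ccc(Cl)cc1` gives only a limit, > 40000 nM.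

Compound 4 `O=C1COc2ccc(-c3cccc(NS(=O)(=O)c4ccc(F)cc4)c3)cc2N1c1ccc(F)cc1` keeps all of compound 1 except that phenyl becomes 4-fluorophenyl, with fluoro in place of hydrogen on an aromatic carbon. For the measured compounds named here, the one measured step that bears on this change is an at least 5.5-fold lower number from compound 2 to compound 3 (0.74 log units; beyond the scatter), where cyclopropyl replaces 4-chlorophenyl on an amide-type nitrogen in a ring. That step swaps a whole group in a different core, so it offers only a weak hint that a halogen on this phenyl brings no gain. No step beyond the scatter is therefore expected in this assay, with a slight rise in the number the likelier direction. The expected outcome is a 1.1-fold higher number from compound 1 to compound 4 (0.05 log units; within the scatter). For compound 4 the estimated value is 20000 nM, with an expected range from 9000 nM to 40000 nM.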

Compound 4, half-maximal inhibitory concentration: > 40000 nM
Compound 4: only a limit was reported (the forecaster's own chance of this, stated with the estimate: 15%); middle value at least 2.0-fold (0.30 log units) from the limit.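

Changing phenyl to 4-fluorophenyl gives an at least 2.2-fold higher number from compound 1 to compound 4 (0.35 log units; beyond the scatter) in this assay, so this position, para to a large group, responds to the addition of a single fluorine atom. The earlier step, an at least 5.5-fold lower number from compound 2 to compound 3 (0.74 log units; beyond the scatter), swapped a whole group on a different core and could not show what one atom does on the core of compound 1. The value of compound 4 is a limit, so the step gives only a minimum size and the full loss stays unknown: the limit of > 40000 nM in this assay, at which 2 of the 4 values shown sit.

As far as these compounds go, it remains open whether a methyl, a methoxy or an amine at this place would behave like fluoro on the core of compound 1. From the compounds shown here alone, it is also open how a cyclopropyl in place of the phenyl of compound 1 would read on that same core.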